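Removing one chloro from compound 1: expected cytotoxicity

A few compounds are considered here, and "the series" means these few. Any claim that something is new, unique, unknown or untested is made for them only; others in the source may bear on it.

Measured in an ADME assay on the whole organism (strain S2) for cytotoxicity, with Drosophila as the target, read by WST assay; on this read-out higher numbers stand for lower toxicity in this test and lower numbers for higher toxicity in this test:
compound 1 `CCCCCC(=O)c1c(O)c(Cl)c(OC)c(Cl)c1O` gives 22500 nM
compound 2 `CCCCCC(=O)c1c(O)c(Cl)c(O)c(Cl)c1O` gives 102000 nM

Of the two numbers, compound 1 holds the lowest; its nearest neighbour is compound 2, the change being a 4.5-fold higher number from compound 1 to compound 2 (0.66 log units; beyond the scatter) in this assay, that step being hydrogen in place of methyl on an oxygen on an aromatic ring.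

Compound 3 `CCCCCC(=O)c1c(O)cc(OC)c(Cl)c1O` has not been measured. It differs from compound 1 by hydrogen in place of chloro on an aromatic carbon. Within the data shown here, the one measured step, hydrogen in place of methyl on an oxygen, concerns a different group and does not bear on the loss of a chloro; no step tests that change. With nothing to argue for a large move in either direction, compound 3 is expected to sit near compound 1, the estimated step being a 1.6-fold higher number from compound 1 to compound 3 (0.19 log units; within the scatter), within the scatter or modest. The expected value for compound 3 in this assay is 35000 nM, with a range from 12000 nM to 100000 nM.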

Compound 3, half-maximal cytotoxic concentration: 8700 nM
Beside the measured number, compound 3's estimate is 4.0-fold (0.60 log units) above it; measured number below the stated range.
By their numbers in this assay, from the lowest: compound 3; then compound 1; then compound 2.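

In this assay, removing the chloro that sits ortho to a hydroxy group and ortho to a methoxy group gives a 2.6-fold lower number from compound 1 to compound 3 (0.41 log units; beyond the scatter) and thus shows that this position is not silent in the read-out, with the loss of the chloro going along with higher toxicity in this test. The earlier step, a 4.5-fold higher number from compound 1 to compound 2 (0.66 log units; beyond the scatter), concerned only the methyl on an oxygen and moved the number the other way, so a change on an aromatic carbon of the shared core is now seen to lower the number. The data at hand offer no measurement that accounts for this step.

Open, on these data alone, is whether a bromo or a methyl at this position would hold the number of compound 1 or follow compound 3. Also open, as far as these compounds go, is whether the remaining chloro behaves in the same way, and whether the step on the methyl carries over to a core lacking this chloro.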